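From thiophen-3-yl to 1-benzofuran-2-yl: little change expected

A few compounds are considered here, and "the series" means these few. Any claim that something is new, unique, unknown or untested is made for them only; others in the source may bear on it.

- Compound 1 `CN(C)c1ncnc2c1c(-c1cc3ccccc3o1)cn2[C@@H]1O[C@H](CO)[C@@H](O)[C@H]1O` gives > 20000 nM (a limit)
- Compound 2 `Cc1ncnc2c1c(-c1ccoc1)cn2[C@@H]1O[C@H](CO)[C@@H](O)[C@H]1O` gives > 20000 nM (a limit)
- Compound 3 `Cc1ncnc2c1c(-c1ccsc1)cn2[C@@H]1O[C@H](CO)[C@@H](O)[C@H]1O` gives 14300 nM (a number)

Among the compounds with values here, in a functional assay on HeLa S3 cells (Homo sapiens) for antiproliferative activity, read by XTT assay, with a stated time of 72 h (a lower number here means a stronger inhibitor, a higher number a weaker inhibitor), compound 3 gives 14300 nM as the only real number available. Beyond it there is only the limit of > 20000 nM in this assay, at which 2 of the 3 values shown sit, for comparison.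

Compound 4 `Cc1ncnc2c1c(-c1cc3ccccc3o1)cn2[C@@H]1O[C@H](CO)[C@@H](O)[C@H]1O` is still unmeasured, and 1-benzofuran-2-yl in place of thiophen-3-yl on an aromatic carbon sets out how it differs from compound 3: 1-benzofuran-2-yl in place of thiophen-3-yl on an aromatic carbon.

Within the data shown here, the one measured step is an at least 1.3-fold lower number from compound 2 to compound 3 (0.14 log units; that floor lies within the scatter) with thiophen-3-yl in place of furan-3-yl, which gives no firm guide to size or direction. Compound 1 also carries 1-benzofuran-2-yl and gives > 20000 nM as a limit. With so little to go on, the expected change is a 1.1-fold higher number from compound 3 to compound 4 (0.05 log units; within the scatter) and no shift beyond the scatter is expected. For compound 4 the estimated value is 16000 nM within an expected range of 5000 nM to 30000 nM and a reading at the limit is quite likely.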

Compound 4, half-maximal inhibitory concentration: > 20000 nM
Compound 4: only a limit was reported (the forecaster's own chance of this, stated with the estimate: 60%); middle value at least 1.2-fold (0.09 log units) from the limit.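

In this assay compound 4 gives > 20000 nM, which is a limit and not a number, so enlarging the group at this position to 1-benzofuran-2-yl, with its added six-membered aromatic ring of carbon only, brings no measurable gain. The change is an at least 1.3-fold higher number from compound 3 to compound 4 (0.14 log units; that floor lies within the scatter), so a real loss is not established either, and the steps that join two limits cannot be read. Compound 3 keeps the only number shown, and the other compounds give no scale to set it against: the limit of > 20000 nM in this assay, at which 3 of the 4 values shown sit.

From the compounds shown here alone, it remains open whether a different group at this position, such as an amine or a phenyl ring, would give a clearly lower number on the shared core. Going by these compounds, the effect of dimethylamino in place of methyl also remains open, as both compounds that show this change sit at the limit.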